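A few compounds are considered here, and "the series" means these few. Any claim that something is new, unique, unknown or untested is made for them only; others in the source may bear on it.

Compound 1 `CC(=O)N1CCN(c2ccc(Nc3ncc(C#N)c(-c4c[nH]c5ccccc45)n3)cc2)CC1`: 4 nM. Compound 2 `CC(=O)N1CCN(c2ccc(Nc3nccc(-c4cn(C)c5ccccc45)n3)cc2)CC1`: 252 nM.

In a functional assay on MV4-11 cells (Homo sapiens) for antiproliferative activity, read by resazurin assay, with a stated time of 72 h (on this read-out higher numbers stand for weaker inhibition of growth and lower numbers for stronger inhibition of growth), compound 2 gives the higher of the two numbers, and compound 1 sits far below it. These two compounds differ in more than one place, so only their two values can be compared. Compound 3 `CC(=O)N1CCN(c2ccc(Nc3nccc(-c4c[nH]c5cccnc45)n3)cc2)CC1` differs from compound 2 by a group of 9 heavy atoms (7 carbon, 2 nitrogen; one five-membered aromatic ring with 1 hetero atom, one six-membered aromatic ring with 1 hetero atom) in place of a group of 10 heavy atoms (9 carbon, 1 nitrogen; one five-membered aromatic ring with 1 hetero atom, one six-membered aromatic ring of carbon only), on an aromatic carbon. Among the compounds with values here, no measured pair shows this change alone. Because compound 1, whose group at that position also carries a hydrogen-bond donor, gives 4 nM, compound 3 is expected to inhibit growth more strongly than compound 2. The expected step is a 6.3-fold lower number from compound 2 to compound 3 (0.80 log units; beyond the scatter). Compound 3 is estimated at 40 nM, between 8 nM and 200 nM.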

Compound 3, concentration for 50% growth inhibition: 420 nM
Beside the measured number, compound 3's estimate is 11-fold (1.02 log units) below it; measured number outside the range, above it.
By their numbers in this assay, from the lowest: compound 1; then compounds 2 and 3 (each within the scatter of the next).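

In this assay, putting the group with a hydrogen-bond donor and a nitrogen in its six-membered ring in place of 1-methyl-1H-indol-3-yl gives a 1.7-fold higher number from compound 2 to compound 3 (0.22 log units; within the scatter). Compound 2 and compound 3 therefore cannot be told apart, and a hydrogen-bond donor arriving with this change does not by itself separate them. No measurement shown here explains this result. Going by these compounds, the swap alters several features at once, so the share of each remains open. Also open, on these data alone, is what an amine or a fluorine atom on the six-membered ring of the entering group would do.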